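Second methyl on the ketone-bearing ring of compound 2

The source may hold more compounds than are shown below. What is called first, only, known or untested is meant among the compounds shown, and "the series" means these compounds.

Compound 1 `C=C(C)C(=O)c1ccc(OCc2nc(-c3ccc(C(F)(F)F)cc3)no2)cc1C` and compound 2 `C=C(C)C(=O)c1ccc(OCc2nc(-c3ccc([N+](=O)[O-])cc3)no2)cc1C` differ only by the nitro in place of the trifluoromethyl. In an assay on HL-60 cells for inhibition of glutathione S-transferase P (Homo sapiens) (a higher number here means a weaker inhibitor, a lower number a stronger inhibitor), compound 1 gives 3300 nM and compound 2 gives 2900 nM; the step of a 1.1-fold lower number from compound 1 to compound 2 (0.06 log units; within the scatter) lies within the scatter, so on these two numbers compound 2 cannot be told apart from compound 1. Compound 3 `C=C(C)C(=O)c1ccc(OCc2nc(-c3ccc([N+](=O)[O-])cc3)no2)c(C)c1C` carries methyl in place of hydrogen on an aromatic carbon. Going by the values given here, no measured step touches that ring, so nothing bears directly on the change; the one step available concerns a different ring. Compound 3 is therefore expected at 2900 nM, between 1200 nM and 7000 nM, a step of no change at the digits printed from compound 2 to compound 3 (within the scatter) expected to stay within the scatter.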

Compound 3, half-maximal inhibitory concentration: 2300 nM
For compound 3 the middle estimate is 1.3-fold (0.10 log units) above the measured one; the measured number falls inside the stated range.
By their numbers in this assay, from the lowest: compounds 3, 2 and 1 (each within the scatter of the next).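

In this assay the methyl in place of hydrogen, on an aromatic carbon ortho to a large group and ortho to a methyl group, gives a 1.3-fold lower number from compound 2 to compound 3 (0.10 log units; within the scatter) and so shows no change that can be told from the scatter. This is the only step shown on the ketone-bearing ring, and the ring carries a second methyl here without a readable loss or gain. Nothing available accounts for this result.

As far as these compounds go, whether an amine, a methoxy group or a longer chain at this position would also leave the number within the scatter remains open. Also open, from the compounds shown here alone, is whether the methyl gives the same step with trifluoromethyl in place of nitro.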